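Acetyl in Place of Methylsulfonyl: What to Expect

This account rests on a few compounds, and the source may have more. Where it says the series, first, only, none or still open, it means among the compounds named here.

Compound 1, `C[C@]1(CO)[C@H]2CC[C@](C)(O)[C@@H](/C=C/c3ccc(-c4cccc(F)c4)cn3)[C@]2(C)CC[C@H]1O`: in a functional assay on HEK293 cells for antagonist activity at proteinase-activated receptor 1 (Homo sapiens), read by FLIPR and calcium flux, with a stated time of 15 min (on this read-out higher numbers stand for weaker inhibition and lower numbers for stronger inhibition), compound 1 gives 55000 nM.
Compound 2, `C[C@@]12CC[C@@H](O)[C@@](C)(C3SCCS3)[C@H]1CC[C@H](C1SCCS1)[C@H]2/C=C/c1ccc(-c2cccc(F)c2)cn1`: in this assay compound 2 reaches only a limit of the assay, > 100000 nM.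
Compound 3, `C[C@H]1CC[C@@H]2C(C)(C)[C@H](OS(C)(=O)=O)CC[C@@]2(C)[C@@H]1/C=C/c1ccc(-c2cccc(F)c2)cn1`: in this assay compound 3 gives 87000 nM.

Of the two measured numbers, compound 3 holds the higher one, while compound 1 sits close to it; the gap between the two lies within the usual scatter of repeated measurements, so the two cannot be ranked against each other. For compound 2 only a limit is known, (the limit of > 100000 nM in this assay, at which 1 of the 3 values shown sits), and it therefore gives no number to compare.

Compound 4, `CC(=O)O[C@@H]1CC[C@@]2(C)[C@H](/C=C/c3ccc(-c4cccc(F)c4)cn3)[C@@H](C)CC[C@@H]2C1(C)C`, has not yet been measured. It differs from compound 3 in a single place: acetyl in place of methylsulfonyl on an oxygen on a saturated carbon. Within the data shown here, no pair of measured compounds shows such a change, so the size of this step cannot be read from the data. The step from compound 3 to compound 4 is expected to be a 1.1-fold lower number from compound 3 to compound 4 (0.04 log units; within the scatter), that is, no change beyond the scatter in either direction. In this assay compound 4 is accordingly estimated at 80000 nM, with a range from 30000 nM to 200000 nM.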

Compound 4, half-maximal inhibitory concentration: > 100000 nM
Compound 4: only a limit was reported; the forecaster's own chance of this, stated with the estimate: 35%; middle value at least 1.2-fold (0.09 log units) away from the limit.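

Among these compounds, the change of (methylsulfonyl)oxy to acetoxy gives the first view of this position, on an oxygen on a saturated carbon, since the earlier compounds offered no pair that differs there. In this assay it reads as an at least 1.1-fold higher number from compound 3 to compound 4 (0.06 log units; that floor lies within the scatter), which shows that acetyl in place of methylsulfonyl brings no stronger inhibition, although only a floor is known for the step and that floor cannot establish a real loss. Compound 4 gives only a limit of the assay, > 100000 nM, and so joins the compounds that carry no number at the top of the range: the limit of > 100000 nM in this assay, at which 2 of the 4 values shown sit.

As far as these compounds go, how far compound 4 lies past that limit remains open, and with it whether methylsulfonyl and acetyl truly differ at this position or simply sit close together at the weak end of the range. Also open is whether a free hydroxyl, an amine, a carboxylic acid or a longer acyl chain on this carbon would move the number at all, since the two groups shown give no direction for such a change.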